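The compounds below may be only part of what the source reports. "The series", "measured", "known", "first", "only" and "open" are said of these compounds alone.

Measured compounds:
- Compound 1, `COc1cc2c(Oc3ccc(NC(=O)c4nn(-c5ccccc5OC(F)(F)F)c(=O)cc4C)cc3F)ccnc2cc1OCCCN1CCC(C)CC1`: 800 nM
- Compound 2, `COc1cc2c(Oc3ccc(NC(=O)c4nn(-c5ccccc5OC(F)(F)F)c(=O)cc4C)cc3F)ccnc2cc1OCCCN1CCN(C)CC1`: 1440 nM
- Compound 3, `COc1cc2c(Oc3ccc(NC(=O)c4nn(-c5cccc(F)c5)c(=O)cc4C)cc3F)ccnc2cc1OCCCN1CCC(C)CC1`: 1800 nM

Three compounds were tested in a functional assay on U-87MG ATCC cells (Homo sapiens) for inhibition, read by MTT assay, with a stated time of 72 h; a higher number here means a weaker inhibitor, a lower number a stronger inhibitor. Compound 1 gave 800 nM in this assay; compound 2 gave 1440 nM, and compound 3 gave 1800 nM. The structural change from compound 1 to compound 2 is 4-methylpiperazin-1-yl in place of 4-methylpiperidin-1-yl on a saturated chain carbon, three bonds along the chain from an oxygen on an aromatic ring, and it produced a 1.8-fold higher number from compound 1 to compound 2 (0.26 log units; within the scatter). Compound 3 differs from compound 1 in another place, (3-fluorophenyl in place of 2-(trifluoromethoxy)phenyl on an aromatic nitrogen), with a 2.3-fold higher number from compound 1 to compound 3 (0.35 log units; beyond the scatter).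

Compound 4, `COc1cc2c(Oc3ccc(NC(=O)c4nn(-c5cccc(F)c5)c(=O)cc4C)cc3F)ccnc2cc1OCCCN1CCN(C)CC1`, has not yet been measured in this assay. It relates to compound 3 as compound 2 relates to compound 1: the change is 4-methylpiperazin-1-yl in place of 4-methylpiperidin-1-yl on a saturated chain carbon, three bonds along the chain from an oxygen on an aromatic ring, made at a place described in the same words as for the first pair, so the two changes can be called the same change on two different cores. The cores differ as the difference between compound 1 and compound 3 shows.

Within the data shown here, the expectation for compound 4 rests on the single earlier instance of this change, which gave a 1.8-fold higher number from compound 1 to compound 2 (0.26 log units; within the scatter), a step that sits within the usual scatter. Starting from compound 3 at 1800 nM, a similar drift is expected, a 1.8-fold higher number from compound 3 to compound 4 (0.25 log units; within the scatter), though with only one precedent the step could just as well be flat. Compound 4 is therefore estimated at 3200 nM in this assay, with a range from 1400 nM to 7500 nM.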

Compound 4, half-maximal inhibitory concentration: 1590 nM
Estimate against measurement, compound 4: 2.0-fold (0.30 log units) above, within the range that was stated.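

In this assay, among these compounds, putting 4-methylpiperazin-1-yl in place of 4-methylpiperidin-1-yl on the core of compound 3 gave a 1.1-fold lower number from compound 3 to compound 4 (0.05 log units; within the scatter) and, set beside the first instance of that change, the new step cannot be told apart from it: the same change on two cores in this assay, a 1.8-fold higher number (0.26 log units; within the scatter) from compound 1 to compound 2 and a 1.1-fold lower number (0.05 log units; within the scatter) from compound 3 to compound 4, 2.0-fold (0.31 log units) apart, within the scatter of two such steps. Putting 3-fluorophenyl in place of 2-(trifluoromethoxy)phenyl on the aromatic nitrogen of the 4-methylpiperazin-1-yl compounds gave a 1.1-fold higher number from compound 2 to compound 4 (0.04 log units; within the scatter) and this step, too, cannot be told apart from its earlier instance: the same change on two cores in this assay, a 2.3-fold higher number (0.35 log units; beyond the scatter) from compound 1 to compound 3 and a 1.1-fold higher number (0.04 log units; within the scatter) from compound 2 to compound 4, 2.0-fold (0.31 log units) apart, within the scatter of two such steps. Among the compounds shown here, both changes therefore carried from one core to the other with no gap that stands clear of the scatter, but a single pair of steps for each change does not show that either step has a fixed size, and the one step printed as beyond the scatter, a 2.3-fold higher number from compound 1 to compound 3 (0.35 log units; beyond the scatter), was not matched by a step beyond the scatter on the second core.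

The compounds shown leave open whether a morpholine or a dimethylamino group at the end of the chain, or a longer chain, would follow the same course. They also leave open how a plain phenyl on the aromatic nitrogen would compare on either core.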